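From a 4-fluorobenzyl to a 3-chlorobenzyl group

The compounds below may be only part of what the source reports. "The series", "measured", "known", "first", "only" and "open" are said of these compounds alone.

Compound 1 `COc1ccc(/C=C2\CN(C(=S)SCc3cn(Cc4ccccc4F)nn3)C/C(=C\c3ccc(OC)cc3)C2=O)cc1` gives 54500 nM 
Compound 2 `O=C1/C(=C/c2ccccc2F)CN(Cc2cn(Cc3cccc(Cl)c3)nn2)C/C1=C\c1ccccc1F` gives 4300 nM 
Compound 3 `Cc1ccc(/C=C2\CN(C(=S)SCc3cn(Cc4ccc(F)cc4)nn3)C/C(=C\c3ccc(C)cc3)C2=O)cc1` gives 38800 nM 

In a functional assay on DU-145 cells (Homo sapiens) for cytotoxicity, read by MTT assay, with a stated time of 24 h (a lower number here means a stronger inhibitor, a higher number a weaker inhibitor), compound 3 gives 38800 nM and sits within the scatter of compound 1 (54500 nM). Compound 2 (4300 nM) has a lower number than compound 3, a gap beyond the scatter, and so is the stronger inhibitor of that pair.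

Compound 4 `Cc1ccc(/C=C2\CN(C(=S)SCc3cn(Cc4cccc(Cl)c4)nn3)C/C(=C\c3ccc(C)cc3)C2=O)cc1` carries 3-chlorophenyl in place of 4-fluorophenyl on a saturated chain carbon bound to an aromatic nitrogen, and is otherwise the same as compound 3. Going by the values given here, no measured pair isolates this change. Compound 2 also carries 3-chlorophenyl at that place, but it differs from compound 4 elsewhere as well, which makes it a poor guide. Compound 1 and compound 3 differ in more than one place, yet compound 3 at 38800 nM and compound 1 at 54500 nM still lie within the scatter of each other.

In this assay the expected step of a 1.3-fold lower number from compound 3 to compound 4 (0.11 log units; within the scatter) is small, staying within the scatter with a slight lean towards a lower number. The estimated value for compound 4 is 30000 nM (expected range 12000 nM to 65000 nM).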

Compound 4, half-maximal inhibitory concentration: > 80000 nM
Compound 4: only a limit was reported; the forecaster's own chance of this, stated with the estimate: 5%; middle value at least 2.6-fold (0.42 log units) away from the limit.
By their numbers in this assay, from the lowest: compound 2; then compounds 3 and 1 (each within the scatter of the next). At a limit, above all of these: compound 4.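

In this assay compound 4 is reported only as a limit, > 80000 nM. Going by these compounds alone, replacing 4-fluorobenzyl with 3-chlorobenzyl, with the rest of the structure unchanged, gives an at least 2.0-fold higher number from compound 3 to compound 4 (0.31 log units; beyond the scatter), the first step here that isolates this place on a saturated chain carbon bound to an aromatic nitrogen, which the earlier compounds could not do, as they differ from one another in more than one place. This shows that the number in this assay responds to this change at this place, although the size of the step is open on one side and rests on a reported limit rather than on a number: the limit of > 80000 nM in this assay, at which 1 of the 4 values shown sits.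

The change replaces the halogen and moves it on the ring in a single step, so the compounds shown do not separate these two differences. As far as these compounds go, how a plain benzyl group, or a benzyl group carrying an amine or a carboxylic acid, would read at this place in this assay also remains open.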